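Adding a second chlorine to the pendant aryl ring

The source may report more compounds than this note shows. Statements on the series, on what has been measured and on what is new or still open speak of the compounds shown alone.

Measured so far:
compound 1, `CCOC(=O)c1c(-c2ccc(Cl)c(Cl)c2)cc(-c2ccccc2)nc1Nc1ccc(C)cc1`, 87.9%
compound 2, `CCOC(=O)c1c(-c2ccc(Cl)cc2)cc(-c2ccccc2)nc1Nc1ccc(Cl)cc1`, 95.9%

Both compounds were examined in a functional assay on the whole organism (strain Wister albino) for inhibition, with Rattus norvegicus as the target, read by paw edema, with stated times of 1 h and 4 h, at a dose of 50 mg/kg by the intraperitoneal route; a lower number here means less inhibition, a higher number more inhibition at the dose given (going by the name of the read-out). Compound 1 gives 87.9%, and compound 2 gives 95.9%. Compound 2 therefore carries the higher of the two numbers, but the gap to compound 1 lies within the scatter of the measurement, so the two results cannot be told apart with confidence. Among the compounds with values here, no single-point step between the two measured compounds exists, since they differ in two places at once.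

Compound 3, `CCOC(=O)c1c(-c2ccc(Cl)c(Cl)c2)cc(-c2ccccc2)nc1Nc1ccc(Cl)cc1`, has not yet been measured in this assay. It departs from compound 2 by one change: chloro in place of hydrogen on an aromatic carbon. Reading the difference one bond further out, the 4-chlorophenyl of compound 2 becomes the 3,4-dichlorophenyl that compound 1 also carries.

Because compound 1 gives 87.9% with that same 3,4-dichlorophenyl, and compound 2 gives 95.9%, the step of a number 5.9 percentage points lower from compound 2 to compound 3 (within the scatter) is expected to be small and to stay within the scatter, with no clear direction. Compound 3 is thus estimated at 90% in this assay, with a range from 80% to 98%.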

Compound 3, a percentage reported as inhibition, in the whole organism at one dose (the size of the read-out at that dose, not a potency): 91.8%
Estimate against measurement, compound 3: 1.8 percentage points below, within the range that was stated.
By their numbers in this assay, from the lowest: compounds 1, 3 and 2 (each within the scatter of the next).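

In this assay, within the data shown here, the second chlorine that turns the 4-chlorophenyl into the 3,4-dichlorophenyl gives a number 4.1 percentage points lower from compound 2 to compound 3 (within the scatter) and so offers the first reading of this change on its own: chloro in place of hydrogen, at a place ortho to a chloro group, leaves a difference that cannot be told from the scatter. Compound 3 also connects compound 1 to the series through a second single change, since chloro in place of methyl on an aromatic carbon gives a number 3.9 percentage points higher from compound 1 to compound 3 (within the scatter) and is likewise unresolved, so neither of the two places has yet produced a clear difference at this dose. No other measurement bears on these two steps, and nothing shown accounts for them.

Going by these compounds, whether a methoxy group, an amine or a carboxylic acid on the same aromatic carbon would also stay level with compound 2 remains open. Because each reading comes from a single dose, the compounds shown also leave open whether compounds this close at that dose would still match one another at lower doses.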